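Removing One Methoxy Group from a Trimethoxy Aryl Chalcone

The compounds below may be only part of what the source reports. "The series", "measured", "known", "first", "only" and "open" are said of these compounds alone.

Measured compounds:
Compound 1 `COc1ccc(-c2cc(/C=C/C(=O)c3ccc(N)cc3)[nH]n2)cc1`: 1420 nM
Compound 2 `COc1ccc(-c2cc(/C=C/C(=O)c3ccc(N)cc3)[nH]n2)cc1OC`: 2030 nM
Compound 3 `COc1cc(C(=O)/C=C/c2cc(-c3cc(OC)c(OC)c(OC)c3)n[nH]2)cc(OC)c1OC`: 2960 nM

In a functional assay on K562 cells (Homo sapiens) for inhibition, read by sulforhodamine B assay, with a stated time of 48 h (on this read-out lower numbers stand for stronger inhibition of growth and higher numbers for weaker inhibition of growth), compound 1 gives 1420 nM, compound 2 gives 2030 nM and compound 3 gives 2960 nM. Compound 3 shows the highest of the three numbers, but its difference from compound 2 lies within the scatter; only against compound 1 does it lie beyond it. Between compound 2 and compound 1 the change hydrogen in place of methoxy on an aromatic carbon yields a 1.4-fold lower number from compound 2 to compound 1 (0.16 log units; within the scatter).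

Compound 4 `COc1ccc(-c2cc(/C=C/C(=O)c3cc(OC)c(OC)c(OC)c3)[nH]n2)cc1OC` is not yet measured. It differs from compound 3 by hydrogen in place of methoxy on an aromatic carbon. This is the same kind of change as that from compound 2 to compound 1, though the surroundings differ: in compound 3 the carbon is also meta to a methoxy group. The difference between the cores of compound 2 and compound 3 is not broken down here.

Because a 1.4-fold lower number from compound 2 to compound 1 (0.16 log units; within the scatter) stayed within the scatter, compound 4 is expected to give 2300 nM, a step of a 1.3-fold lower number from compound 3 to compound 4 (0.11 log units; within the scatter), most likely between 1100 nM and 5000 nM.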

Compound 4, concentration for 50% growth inhibition: 730 nM
The estimate for compound 4 lay 3.2-fold (0.50 log units) above the measured number; the measured number lies below the stated range.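

Putting hydrogen in place of methoxy on an aromatic carbon gives a 4.1-fold lower number from compound 3 to compound 4 (0.61 log units; beyond the scatter) in this assay, and the size of this step did not carry over from one core to the other: the same change on two cores in this assay, a 1.4-fold lower number (0.16 log units; within the scatter) from compound 2 to compound 1 and a 4.1-fold lower number (0.61 log units; beyond the scatter) from compound 3 to compound 4, 2.8-fold (0.45 log units) apart, beyond the scatter of two such steps

Within this series, then, a step read on one core cannot be assumed for another, and only the step on the core of compound 3 lies beyond the scatter. These two pairs do not show which part of the cores sets the gap, nor how the change would behave on any further core.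

The compounds shown leave open whether a hydroxyl group or a fluorine atom on that aromatic carbon would give a number closer to that of compound 3 or that of compound 4.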